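The source may hold more compounds than are shown below. What is called first, only, known or untested is meant among the compounds shown, and "the series" means these compounds.

In a functional assay on MDA-MB-231 cells (Homo sapiens) for antiproliferative activity, read by MTT assay, with a stated time of 72 h (a higher number here means a weaker inhibitor, a lower number a stronger inhibitor), compound 1 `NS(=O)(=O)c1ccc(S(=O)(=O)Nc2cccc(-c3nc(-c4ccc(NC(=O)c5cccnc5)cc4Cl)no3)c2)cc1` gives > 10000 nM, which is a limit and not a number. Compound 2 `Cc1ccc(S(=O)(=O)Nc2cccc(-c3nc(-c4ccc(NC(=O)c5cccnc5)cc4Cl)no3)c2)cc1` gives > 10000 nM, again a limit. Compound 3 `COc1cccc(S(=O)(=O)Nc2cccc(-c3nc(-c4ccc(NC(=O)c5cccnc5)cc4Cl)no3)c2)c1` gives > 10000 nM, also a limit, and this is all that is known about where it stands. The evidence is therefore a single shared ceiling: the limit of > 10000 nM in this assay, at which 3 of the 3 values shown sit.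

The next compound, compound 4 `Cc1ccc(NC(=O)Nc2cccc(-c3nc(-c4ccc(NC(=O)c5cccnc5)cc4Cl)no3)c2)cc1`, keeps the shared core but carries (4-methylphenyl)carbamoyl in place of (3-methoxyphenyl)sulfonyl on a nitrogen on an aromatic ring. The counted difference is (4-methylphenyl)carbamoyl in place of (3-methoxyphenyl)sulfonyl on a nitrogen on an aromatic ring.

Three measured steps could bear on this change: a step that the two limits leave unreadable from compound 1 to compound 2, a step that the two limits leave unreadable from compound 1 to compound 3 and a step that the two limits leave unreadable from compound 2 to compound 3. None has a readable size, and in all three the sulfonyl group stays in place. They therefore offer no size to carry over to the new change.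

A readable number for compound 4 would have to fall on the stronger side of the ceiling, so any expected movement in this assay points that way, although another limit remains quite possible. The expected change is an at least 1.6-fold lower number from compound 3 to compound 4 (0.22 log units; that floor lies within the scatter), a tentative figure. For compound 4, the estimated value is 6000 nM, with an expected range from 800 nM to 20000 nM.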

Compound 4, half-maximal inhibitory concentration: 3500 nM
For compound 4 the middle estimate is 1.7-fold (0.23 log units) above the measured one; low and high end bracket the measured number.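

Among compound 1, compound 2 and compound 3 the steps cannot be read, and all of them keep the sulfonyl group, so they said nothing about changing that group on this nitrogen; replacing it now gives a readable result in this assay for the first time in this set. With 4-methylphenyl kept and only sulfonyl giving way to carbamoyl, the data show an at least 2.8-fold lower number from compound 2 to compound 4 (0.45 log units; beyond the scatter) as the cleanest comparison on offer. The change that also swaps the aryl group shows an at least 2.8-fold lower number from compound 3 to compound 4 (0.45 log units; beyond the scatter) at the same printed size, and neither size is exact, since both rest on one shared limit: the limit of > 10000 nM in this assay, at which 3 of the 4 values shown sit.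

As far as these compounds go, the true size of the gain stays open, as does whether carbamoyl would give a readable value with 3-methoxyphenyl or 4-sulfamoylphenyl attached in place of 4-methylphenyl. The compounds shown also leave open how a small acetyl group on this nitrogen, or a free amine with nothing attached, would behave in this assay compared with the carbamoyl of compound 4.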